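Aryl-for-aryl swap on the ring-amine side chain

The compounds below may be only part of what the source reports. "The series", "measured", "known", "first", "only" and "open" are said of these compounds alone.

Measured so far in a functional assay on the whole organism for antagonist activity, with Mus musculus as the target; on this read-out higher numbers stand for an effect only at larger amounts of compound and lower numbers for an effect already at smaller amounts:
compound 1 `COc1cc(N)c(Cl)cc1NC(=O)C1CCN(CC2CC2)CC1` — > 10 mg/kg
compound 2 `COc1cc(N)c(Cl)cc1NC(=O)C1CCN(Cc2ccc(Cl)cc2)CC1` — 1.2 mg/kg
compound 3 `COc1cc(N)c(Cl)cc1NC(=O)C1CCN(CC2CCC2)CC1` — > 10 mg/kg

Going by the values given here, compound 2 holds the only real number in this assay; it stands alone. For compound 1 this assay returns only a limit, not a number. For compound 3 the result is likewise only a limit. Both limits sit at the same point (the limit of > 10 mg/kg in this assay, at which 2 of the 3 values shown sit).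

The two readable steps both concern the group on the saturated chain carbon bound to the amine nitrogen in the ring: an at least 8.3-fold lower number from compound 1 to compound 2 (0.92 log units; beyond the scatter), and in the reverse sense an at least 8.3-fold higher number from compound 2 to compound 3 (0.92 log units; beyond the scatter). The pair of limits gives a step that the two limits leave unreadable from compound 1 to compound 3. So far the data show only that the 4-chlorophenyl compound sits well below the limit where the two small cycloalkyl compounds sit.

Compound 4 `COc1cc(N)c(Cl)cc1NC(=O)C1CCN(Cc2ccc(C)c(C)c2)CC1` keeps an aryl group at that position: 3,4-dimethylphenyl in place of 4-chlorophenyl on a saturated chain carbon bound to an amine nitrogen in a ring. Neither measured step compares two aryl groups, so neither bears directly on this change; both trade aryl for cycloalkyl. With an aryl group retained, a step of the size seen for compound 2 to compound 3 is not expected; a change within or slightly beyond the scatter is. Compound 4 is estimated at 2 mg/kg, between 0.6 mg/kg and 8 mg/kg. This corresponds to an expected step of a 1.7-fold higher number from compound 2 to compound 4 (0.22 log units; within the scatter).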

Compound 4, dose for half-maximal effect: > 8 mg/kg
Compound 4: no number, only a limit; the forecaster's own chance of this, stated with the estimate: 20%; middle value at least 4.0-fold (0.60 log units) away from the limit.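

In this assay compound 4 gives > 8 mg/kg, which is a limit of the assay and not a number. Going by these compounds alone, the change from 4-chlorophenyl to 3,4-dimethylphenyl is the first comparison of two aryl groups at this position on a saturated chain carbon bound to an amine nitrogen in a ring, and it gives an at least 6.6-fold higher number from compound 2 to compound 4 (0.82 log units; beyond the scatter), so keeping an aryl group there does not by itself keep a measurable number. Compound 2 remains the only one of the four compounds with a real number, while the steps joining compound 4 to compound 1 and compound 3 cannot be read, since each links two limits: the limit of > 8 mg/kg in this assay, at which 1 of the 4 values shown sits.

The shown compounds do not separate the removal of the chlorine from the addition of the two methyl groups, and unsubstituted benzyl or 4-fluorobenzyl at this position would bear directly on that question. As far as these compounds go, how far compound 1, compound 3 and compound 4 lie beyond their limits, and whether they differ from one another at all, also remains open.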